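Swapping the Aryl Group on the Carbonyl Carbon

The compounds below may be only part of what the source reports. "The series", "measured", "known", "first", "only" and "open" are said of these compounds alone.

Measured so far:
Compound 1, `N=C(N)N/N=C/c1ccc(/C=C/C(=O)c2ccc(Cl)cc2)cc1`, in a functional assay on the whole organism (Ear) for inhibition, with Mus musculus as the target, with a stated time of 30 min, at a dose of 100 mg/kg by the intraperitoneal route; on this read-out higher numbers stand for more inhibition at the one dose given (going by the name of the read-out) and lower numbers for less inhibition: 56.4%
Compound 2, `Cc1ccc(C(=O)/C=C/c2ccc(/C=N/NC(=N)N)cc2)c(C)c1`, in this assay : 64.2%

On these two numbers compound 2 stands highest, with compound 1 its nearest neighbour. Going by the values given here, the single measured step between them, a number 7.8 percentage points higher from compound 1 to compound 2 (within the scatter), lies within the scatter, so the two compounds cannot be ranked against each other on this evidence, and the number of compound 2 cannot be called higher than that of compound 1.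

Compound 3, `N=C(N)N/N=C/c1ccc(/C=C/C(=O)c2ccccc2Br)cc1`, differs from compound 2 in one place: 2-bromophenyl in place of 2,4-dimethylphenyl on a carbonyl carbon.

Among the compounds with values here, the only measured step that bears on this change is a number 7.8 percentage points higher from compound 1 to compound 2 (within the scatter), since it too exchanged the aryl group on the carbonyl carbon, and it stayed within the scatter. One such step is thin evidence, but it gives no reason to expect the new exchange to move the read-out beyond the scatter in either direction. Compound 3 is therefore expected to show a step of a number 6.2 percentage points lower from compound 2 to compound 3 (within the scatter) in this assay, an estimate and not a measurement. Compound 3 is estimated at 58%, within a range from 42% to 74%.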

Compound 3, a percentage reported as inhibition, in the whole organism at one dose (the size of the read-out at that dose, not a potency): 78.3%
Estimate against measurement, compound 3: 20.3 percentage points below; measured number above the stated range.
By their numbers in this assay, from the lowest: compounds 1 and 2 (each within the scatter of the next); then compound 3.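

In this assay, the aryl group on the carbonyl carbon can move the read-out beyond the scatter, which the earlier pair did not show: the exchange to 2-bromophenyl brings a number 14.1 percentage points higher from compound 2 to compound 3 (beyond the scatter) against 2,4-dimethylphenyl and a number 21.9 percentage points higher from compound 1 to compound 3 (beyond the scatter) against 4-chlorophenyl. A halogen on this ring is not enough in itself to set a compound apart, since compound 1, with its 4-chlorophenyl group, cannot be ranked against compound 2, which carries no halogen. No measurement at hand accounts for the standing of the 2-bromophenyl group.

The compounds shown leave open whether the higher number goes with the bromine itself or with its place on the ring, a question that 2-chlorophenyl and 4-bromophenyl groups on the same carbonyl carbon would separate. They also leave open how this position would answer to an aryl ring bearing an amine or a carboxylic acid, or to a saturated group such as cyclohexyl in place of the aryl ring.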